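Replacing a Fluorophenyl Arm in a Cytotoxicity Series

The source may hold more compounds than are shown below. What is called first, only, known or untested is meant among the compounds shown, and "the series" means these compounds.

Measured so far:
compound 1, `CC(C)(C)c1ccc(NC(=S)N/N=C2\C(=O)Nc3ccccc32)cc1`: 6800 nM
compound 2, `CCOC(=O)CC1C(C(=O)OCC)=C(N)Oc2ccc(-c3ccccc3F)cc21`: 73000 nM
compound 3, `C#CCOC(=O)CC1C(C(=O)OCC)=C(N)Oc2ccc(-c3ccc(N)cc3)cc21`: 10500 nM

Of the compounds shown here, three have been tested in a functional assay on HL-60 cells (Homo sapiens) for cytotoxicity, read by CellTiter-Blue, with a stated time of 48 h; on this read-out higher numbers stand for weaker inhibition and lower numbers for stronger inhibition. Compound 1 gives 6800 nM, compound 3 gives 10500 nM, and compound 2 gives 73000 nM. Compound 2 therefore stands at the highest number of the three, and its distance to each of the other two lies beyond the usual scatter, so it is the weakest inhibitor of this small set. For the measured compounds named here, compound 3 shares the core of compound 2 but differs from it in more than one place, so the two values show only that compound 3 sits well below compound 2 on this read-out.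

The compound now waiting for a measurement is compound 4, `CCOC(=O)CC1C(C(=O)OCC)=C(N)Oc2ccc(-c3cccc(C(N)=O)c3)cc21`. It differs from compound 2 in one place: 3-carbamoylphenyl in place of 2-fluorophenyl on an aromatic carbon. Going by the values given here, no single-point step between measured compounds is available to calibrate this change. The account therefore expects a modest step in this assay toward a lower number, one that may still fall close to the scatter, for the step from compound 2 to compound 4 estimated as a 1.8-fold lower number from compound 2 to compound 4 (0.26 log units; within the scatter). Compound 4 is estimated at 40000 nM, within a range from 12000 nM to 130000 nM.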

Compound 4, half-maximal inhibitory concentration: 5400 nM
For compound 4 the middle estimate is 7.4-fold (0.87 log units) above the measured one; measured number outside the range, below it.
By their numbers in this assay, from the lowest: compounds 4, 1 and 3 (each within the scatter of the next); then compound 2.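

In this assay this position of the shared core responds strongly to its substituent: 3-carbamoylphenyl in place of 2-fluorophenyl gives a 14-fold lower number from compound 2 to compound 4 (1.13 log units; beyond the scatter), a large step well beyond the scatter. For the compounds shown here, this is the first comparison that differs in one place, so it ties a change in number to this aromatic carbon alone, with the rest of the molecule unchanged, which the earlier compounds could not do. The result records the size and direction of the step, but no measurement at hand accounts for it.

The change removes the fluorine and introduces the carbamoyl group while also altering where the substituent sits on the phenyl ring, so the compounds shown do not separate these contributions. Going by these compounds, it remains open how a plain phenyl ring would compare at this aromatic carbon, and whether a carboxylic acid or a nitrile in place of the carbamoyl group would keep a number as low as that of compound 4, 5400 nM.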